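Moving one methyl on a dimethylphenyl group

The source may hold more compounds than are shown below. What is called first, only, known or untested is meant among the compounds shown, and "the series" means these compounds.

- compound 1 `Cc1cc(S(N)(=O)=O)ccc1NC(=O)COc1ccc(Cl)cc1NC(=O)c1cccc(Cl)c1` gives 59700 nM
- compound 2 `Cc1cc(S(N)(=O)=O)ccc1NC(=O)COc1ccc(Cl)cc1NC(=O)c1cccc(C(F)(F)F)c1` gives 124000 nM
- compound 3 `Cc1ccc(C(=O)Nc2cc(Cl)ccc2OCC(=O)Nc2ccc(S(N)(=O)=O)cc2C)c(C)c1` gives 47600 nM

These numbers come from a functional assay on C8166 cells (Homo sapiens) for cytotoxicity, read by MTT assay (a lower number here means that less compound is tolerated, a higher number that more compound is tolerated), and all three compounds share one core. Compound 3 lies within the scatter of compound 1, and compound 2 stands clearly higher than both.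

Compound 4 `Cc1ccc(C)c(C(=O)Nc2cc(Cl)ccc2OCC(=O)Nc2ccc(S(N)(=O)=O)cc2C)c1` has not yet been measured. It carries 2,5-dimethylphenyl in place of 2,4-dimethylphenyl on a carbonyl carbon, so the two compounds have the same atoms, joined differently.

Two measured steps changed the group at this place. One is a 1.3-fold lower number from compound 1 to compound 3 (0.10 log units; within the scatter) and the other is a 2.6-fold lower number from compound 2 to compound 3 (0.42 log units; beyond the scatter) and neither is large. Both exchanged one substituted phenyl group for a differently substituted one, a bigger alteration than the one here. For the measured compounds named here, still, no measured compound carries 2,5-dimethylphenyl, so the data offer only indirect guidance.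

On that basis, no step beyond the scatter is expected in this assay for this change. The estimated change is a 1.1-fold higher number from compound 3 to compound 4 (0.04 log units; within the scatter) and would be too small to read as real. For compound 4 the expected value is 52000 nM with an estimated range from 28000 nM to 100000 nM around it.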

Compound 4, half-maximal cytotoxic concentration: 79700 nM
Compound 4: middle estimate off by 1.5-fold (0.19 log units), on the low side, within the range that was stated.
By their numbers in this assay, from the lowest: compounds 3, 1, 4 and 2 (each within the scatter of the next, the first and the last beyond it).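

In this assay, for the compounds shown here, shifting one methyl turns 2,4-dimethylphenyl into 2,5-dimethylphenyl on the carbonyl carbon and gives a 1.7-fold higher number from compound 3 to compound 4 (0.22 log units; within the scatter) and thus no readable difference, so at this place the first swap that keeps the same atoms shows no effect on the number. The new value also fills the gap in the series: the step of a 1.3-fold higher number from compound 1 to compound 4 (0.13 log units; within the scatter) and the step of a 1.6-fold lower number from compound 2 to compound 4 (0.19 log units; within the scatter) both lie within the scatter, although the step of a 2.6-fold lower number from compound 2 to compound 3 (0.42 log units; beyond the scatter) lies beyond it, so the earlier gap no longer separates the dimethylphenyl compounds as a group from the one carrying 3-(trifluoromethyl)phenyl. No measurement shown here speaks to what lies behind these numbers.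

Every group shown at this place is a phenyl ring bearing small substituents, so it stays open whether a cyclohexyl ring, a phenyl ring carrying a carboxylic acid or an amine, or a longer alkyl chain would shift the number beyond the scatter. As far as these compounds go, the other dimethylphenyl isomers, such as 3,5-dimethylphenyl, also remain open, as does any change elsewhere on the shared core.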